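A few compounds are considered here, and "the series" means these few. Any claim that something is new, unique, unknown or untested is made for them only; others in the source may bear on it.

For the measured compounds named here, compound 2 `CC(C)(C)c1ccc(CNCCCNS(=O)(=O)c2cc(C(F)(F)F)cc(C(F)(F)F)c2)cc1` gives the lowest of the three numbers so far in a functional assay on HPAC cells (Homo sapiens) for inhibition, read by MTT assay, with a stated time of 72 h (a higher number here means a weaker inhibitor of growth, a lower number a stronger inhibitor of growth), at 2300 nM. Going by the values given here, compound 3 `COc1cccc(CNCCCNS(=O)(=O)c2cc(C(F)(F)F)cc(C(F)(F)F)c2)c1` sits within the scatter of it, at 2400 nM, so no order can be drawn between the two, and the one step that separates them, a 1.0-fold higher number from compound 2 to compound 3 (0.02 log units; within the scatter), is flat. Compound 1 `O=S(=O)(NCCCNCc1ccccc1Cl)c1cc(C(F)(F)F)cc(C(F)(F)F)c1`, at 10000 nM, stands apart: the steps of a 4.3-fold lower number from compound 1 to compound 2 (0.64 log units; beyond the scatter) and a 4.2-fold lower number from compound 1 to compound 3 (0.62 log units; beyond the scatter) are both beyond the scatter and both modest.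

Compound 4 `O=S(=O)(NCCCNCc1ccc(Cl)cc1)c1cc(C(F)(F)F)cc(C(F)(F)F)c1` differs from compound 2 in one place: chloro in place of tert-butyl on an aromatic carbon. Among the compounds with values here, no measured step swaps exactly these two groups. Within the data shown here, what bears on it is that compound 1, the only other chloro-bearing analogue and carrying 2-chlorophenyl, is the weakest of the three, while compound 2 and compound 3 show that replacing 4-(tert-butyl)phenyl with 3-methoxyphenyl changes nothing. Compound 4 is therefore expected to land between these, with a step of a 1.7-fold higher number from compound 2 to compound 4 (0.24 log units; within the scatter) that may or may not exceed the scatter. Compound 4 is estimated at 4000 nM, between 1500 nM and 10000 nM in this assay.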

Compound 4, concentration for 50% growth inhibition: 2800 nM
Estimate against measurement, compound 4: 1.4-fold (0.15 log units) above, and the stated range covers the measured number.
By their numbers in this assay, from the lowest: compounds 2, 3 and 4 (each within the scatter of the next); then compound 1.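

In this assay, chloro in place of tert-butyl on the aromatic carbon leaves the number flat (a 1.2-fold higher number from compound 2 to compound 4 (0.09 log units; within the scatter)), and 4-chlorophenyl in place of 3-methoxyphenyl is flat as well (a 1.2-fold higher number from compound 3 to compound 4 (0.07 log units; within the scatter)), so these three groups are not told apart here. Compound 1 and compound 4 both carry chloro, yet 4-chlorophenyl in place of 2-chlorophenyl gives a modest step beyond the scatter (a 3.6-fold lower number from compound 1 to compound 4 (0.55 log units; beyond the scatter)), which shows that the place of the chloro on the ring separates these two compounds, not its presence alone. Nothing at hand gives a reason for either result.

From the compounds shown here alone, whether a carboxylic acid, an amine or a nitrile at this place would shift the number remains open. So does the effect of 3-chlorophenyl, or of a longer chain in the shared core.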